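The compounds below may be only part of what the source reports. "The series", "measured", "known", "first", "only" and "open" are said of these compounds alone.

Compound 1 `N#Cc1cccc(S(=O)(=O)c2ccc3c(c2)CCC[C@H]3C=N)c1` and compound 2 `O=C1CN(C[C@@H]2CCCc3cc(S(=O)(=O)c4cccc(F)c4)ccc32)CCN1` share the same core and were both tested in an assay on isolated protein for displacement of a labelled ligand from 5-hydroxytryptamine receptor 6 (Homo sapiens); a lower number here means a stronger inhibitor, a higher number a weaker inhibitor. In this assay compound 1 gives 0.501 nM, while compound 2 gives 6.31 nM, the higher of the two numbers, separated from compound 1 by a gap that lies beyond the usual scatter of the measurement. Compound 3 `NC(=O)NC[C@@H]1CCCc2cc(S(=O)(=O)c3cccc(F)c3)ccc21` has not yet been measured. It differs from compound 2 in one place: ureido in place of 3-oxopiperazin-1-yl on a saturated chain carbon bound to a saturated ring carbon. Within the data shown here, no pair of measured compounds in this set differs by a single change, so nothing measured here shows how such a swap moves the number on its own. The step of a 2.4-fold higher number from compound 2 to compound 3 (0.38 log units; beyond the scatter) is expected to be modest, leaning upward, and may not exceed the scatter. On that basis compound 3 is estimated at 15 nM, with a likely range from 4 nM to 60 nM.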

Compound 3, inhibition constant: 0.2 nM
Compound 3: middle estimate off by 75-fold (1.88 log units), on the high side, and the stated range ends above it.
By their numbers in this assay, from the lowest: compound 3; then compound 1; then compound 2.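

In this assay, among these compounds, the group on a saturated chain carbon bound to a saturated ring carbon turns out to have a strong hold on the number: ureido in place of 3-oxopiperazin-1-yl gives a 32-fold lower number from compound 2 to compound 3 (1.50 log units; beyond the scatter), the first single change that can be read in this set. A six-membered ring at this place is therefore not required for a low number, as the open ureido of compound 3 shows. No measurement here accounts for the size of this step.

The compounds shown leave open whether a simple amine, an acetamide or a methylurea at this place would give a similar number. They also leave open whether ureido has the same effect alongside the nitrile of compound 1 rather than the fluorine of compound 3.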